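Replacing the pyridinyl arm of compound 2 with 4-fluorophenyl

A few compounds are considered here, and "the series" means these few. Any claim that something is new, unique, unknown or untested is made for them only; others in the source may bear on it.

Compound 1 `Cc1[nH]c2ccccc2c1-c1ccnc(N2CCCC2)n1` was tested in an assay on isolated protein for inhibition of interferon-induced, double-stranded RNA-activated protein kinase (Homo sapiens), read by luminescence, with a stated time of 10 min (a higher number here means a weaker inhibitor, a lower number a stronger inhibitor), and gave only a limit, > 100000 nM. Compound 2 `Cc1[nH]c2ccccc2c1-c1ccnc(Nc2cccnc2)n1`, which shares the core, gives 100 nM in this assay. The change from compound 1 to compound 2 is an at least 1000-fold lower number from compound 1 to compound 2 (3.00 log units; beyond the scatter). Compound 2 therefore holds the only number shown in this assay, the other value being a limit, as the one entry at the limit of > 100000 nM in this assay, at which 1 of the 2 values shown sits.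

Compound 3 `Cc1[nH]c2ccccc2c1-c1ccnc(Nc2ccc(F)cc2)n1` is the next compound, not yet measured in this assay. It differs from compound 2 by 4-fluorophenyl in place of pyridin-3-yl on a nitrogen on an aromatic ring. Among the compounds with values here, the single measured step, from compound 1 to compound 2, replaced the whole group on that aromatic carbon, whereas the change to compound 3 keeps the amino link and exchanges one six-membered aromatic ring for another. Within the data shown here, that step therefore bears on this change only loosely, and no step within the amino-linked series is yet known. Compound 3 is expected to stay close to compound 2, with a step from compound 2 to compound 3 estimated at a 1.5-fold higher number from compound 2 to compound 3 (0.18 log units; within the scatter), within the scatter. The estimate for compound 3 in this assay is 150 nM, in the range 40 nM to 600 nM.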

Compound 3, half-maximal inhibitory concentration: 150 nM
Estimate against measurement, compound 3: no gap at the digits printed; measured number inside the range.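

In this assay, the exchange of pyridin-3-yl for 4-fluorophenyl on the nitrogen gives a 1.5-fold higher number from compound 2 to compound 3 (0.18 log units; within the scatter), so compound 2 and compound 3 cannot be told apart, even though the hydrogen-bond acceptor counted in pyridin-3-yl is absent from 4-fluorophenyl. Set against the pyrrolidin-1-yl group of compound 1, the (4-fluorophenyl)amino group gives an at least 660-fold lower number from compound 1 to compound 3 (2.82 log units; beyond the scatter), a large step like the one seen with (pyridin-3-yl)amino, which shows that the large step is not peculiar to pyridin-3-yl and holds for both aromatic arms on the amino link shown. The value of compound 1 is a limit, so both large steps are bounds and not exact sizes: the limit of > 100000 nM in this assay, at which 1 of the 3 values shown sits.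

The exchange changes the ring and adds the fluorine at once, so these compounds do not separate the two, and a plain phenyl would be needed to do so. They also leave open whether an aromatic ring is needed on the amino link at all, as a cyclohexyl or a short alkyl chain there would show, and what a methoxy group or a carboxylic acid on the ring would do.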